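Adding a Methyl Group: From Compound 3 to Compound 4

The compounds below may be only part of what the source reports. "The series", "measured", "known", "first", "only" and "open" are said of these compounds alone.

Measured compounds:
compound 1, `CC#CC(=O)Nc1cccc(Nc2ncnc(Nc3ccc(C(=O)N4CCCCC4)cc3)n2)c1`: 4620 nM
compound 2, `C=CC(=O)Nc1cccc(Nc2ncnc(Nc3ccc(-c4ccc(Cl)nc4)cc3)n2)c1`: "not determined" (no result reported)
compound 3, `C=CC(=O)Nc1cccc(Nc2ncnc(Nc3ccc(C(=O)N4CCCCC4)cc3)n2)c1`: 5140 nM

Compounds 1 and 3 share one core and differ only in the acyl group on the amide. In a functional assay on Raji cells (Homo sapiens) for antiproliferative activity, read by CCK-8 assay, with a stated time of 24 h (a lower number here means a stronger inhibitor, a higher number a weaker inhibitor), compound 1 gives 4620 nM, and compound 3 gives 5140 nM. The step of a 1.1-fold higher number from compound 1 to compound 3 (0.05 log units; within the scatter) is within the scatter, so the two compounds cannot be told apart on these numbers; compound 3 merely carries the higher of the two figures. For compound 2, which carries a chloropyridyl group in place of the piperidine amide, the entry in this assay is "not determined" (no result reported), so no number is available.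

Compound 4, `C=CC(=O)Nc1cc(Nc2ncnc(Nc3ccc(C(=O)N4CCCCC4)cc3)n2)ccc1C`, is compound 3 with one further change: methyl in place of hydrogen on an aromatic carbon.

Among the measured compounds shown here, no measured step touches this position; the only step available, from compound 1 to compound 3, concerns the acyl group and gives no guidance on a ring methyl. Compound 4 is therefore expected to sit close to compound 3, with a step of a 1.0-fold lower number from compound 3 to compound 4 (0.01 log units; within the scatter) that stays within the scatter. The estimate for compound 4 in this assay is 5000 nM, with a range from 2000 nM to 13000 nM.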

Compound 4, half-maximal inhibitory concentration: 30600 nM
Beside the measured number, compound 4's estimate is 6.1-fold (0.79 log units) below it; measured number outside the range, above it.
By their numbers in this assay, from the lowest: compounds 1 and 3 (each within the scatter of the next); then compound 4.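

In this assay, methyl in place of hydrogen on the aromatic carbon ortho to a (vinylcarbonyl)amino group and para to a large group gives a 6.0-fold higher number from compound 3 to compound 4 (0.77 log units; beyond the scatter), a modest step that lies beyond the scatter. Among the compounds shown here, this shows that the position is not indifferent to substitution: compound 4 is a weaker inhibitor than compound 3, whereas the only earlier step, the change of acyl group between compound 1 and compound 3, stayed within the scatter. No available evidence accounts for this rise in the number at this position.

Going by these compounds, whether the weakening is specific to methyl or follows from any group on this carbon remains open; a fluorine atom, a methoxy group or a hydroxyl group there would distinguish the two. Also open, on these data alone, is whether methyl here has the same effect alongside the prop-1-yn-1-yl acyl group of compound 1.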